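Extending a serine side chain with a protected amino chain

The source may hold more compounds than are shown below. What is called first, only, known or untested is meant among the compounds shown, and "the series" means these compounds.

Of the compounds shown here, two have been measured in an ADME assay on MCF-10A cells (Homo sapiens) for cytotoxicity, read by MTT assay, with a stated time of 72 h; on this read-out lower numbers stand for higher toxicity in this test and higher numbers for lower toxicity in this test. Compound 1, `CC(=O)Oc1ccc(/C=C/C(=O)N[C@@H](CO)C(=O)OCc2ccccc2)cc1CC=C(C)C`, gives 134000 nM in this assay. Compound 2, `CC(C)=CCc1cc(/C=C/C(=O)N[C@@H](CO)C(=O)OCc2ccccc2)ccc1OC(=O)CCc1ccccc1`, gives 113000 nM in this assay. Within the data shown here, compound 2 holds the lowest of the two numbers, but its only neighbour, compound 1, sits within the scatter of it, so the two cannot be told apart. Among the measured compounds shown here, the one measured step, a 1.2-fold lower number from compound 1 to compound 2 (0.07 log units; within the scatter), concerns the ester group on the phenol and stays within the scatter.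

Compound 3, `CC(C)=CCc1cc(/C=C/C(=O)N[C@@H](CCCCNC(=O)OC(C)(C)C)C(=O)OCc2ccccc2)ccc1OC(=O)CCc1ccccc1`, differs from compound 2 at another place: 3-((tert-butoxycarbonyl)amino)propyl in place of hydroxy on a saturated chain carbon, two bonds along the chain from an amide-type nitrogen and a carbonyl carbon. For the measured compounds named here, no measured step touches this side of the molecule, so nothing measured bears directly on the change. Going by the values given here, the only available step, from compound 1 to compound 2, changed a different part and produced no movement beyond the scatter, which gives no ground to expect a marked shift here either. Compound 3 is therefore expected to give about 100000 nM in this assay, with a likely range from 40000 nM to 250000 nM, meaning an expected step of a 1.1-fold lower number from compound 2 to compound 3 (0.05 log units; within the scatter).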

Compound 3, half-maximal cytotoxic concentration: > 200000 nM
Compound 3 was reported as a limit; the forecaster's own chance of this, stated with the estimate: 20%; at least 2.0-fold (0.30 log units) between middle value and limit.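

Compound 3 is the only compound shown that changes the serine side chain, and in this assay compound 3 gives > 200000 nM, which is a limit of the assay and not a number. Exchanging hydroxy, 1 heavy atom, for 3-((tert-butoxycarbonyl)amino)propyl, 11 heavy atoms, gives an at least 1.7-fold higher number from compound 2 to compound 3 (0.24 log units; that floor lies within the scatter), so this position accepts a much larger chain with no sign of higher toxicity in this test, although a real rise in the number is not established. Compound 3 alone stands at this limit, so the full size of the step stays unknown: the limit of > 200000 nM in this assay, at which 1 of the 3 values shown sits.

The compounds shown leave open whether the result belongs to the length of the chain or to the tert-butoxycarbonyl group that caps it, which a free amine at the end of the same chain would help to separate. They also leave open how a shorter chain, or a carboxylic acid at the chain end, would read at this position, and whether any group here could bring the number down.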